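Trifluoromethanesulfonamide series: a methyl step on the chain

A few compounds are considered here, and "the series" means these few. Any claim that something is new, unique, unknown or untested is made for them only; others in the source may bear on it.

Measured so far:
compound 1, `CN(CCCn1cc[n+](C)c1/C=N/O)S(C)(=O)=O`, -2.63
compound 2, `CCN(CCCn1cc[n+](C)c1/C=N/O)S(C)(=O)=O`, -2.69
compound 3, `CCN(CCn1cc[n+](C)c1/C=N/O)S(=O)(=O)C(F)(F)F`, -1.03

In a physicochemical assay for lipophilicity (a lower number here means a more polar compound, a higher number a more lipophilic compound), compound 1 gives -2.63. Compound 2 differs from it by methyl in place of hydrogen on a saturated chain carbon bound to a sulfonamide nitrogen, and the step of a number 0.06 log units lower from compound 1 to compound 2 (within the scatter) is within the scatter. Compound 3 gives -1.03 in this assay, the highest of the three numbers; how its core differs from that of compound 1 is not broken down here. The unmeasured compound 4, `CCCN(CCn1cc[n+](C)c1/C=N/O)S(=O)(=O)C(F)(F)F`, differs from compound 3 by methyl in place of hydrogen on a saturated chain carbon, two bonds along the chain from a sulfonamide nitrogen. This is the same kind of change as from compound 1 to compound 2, but not the same: there the place was bound to a sulfonamide nitrogen, here it is two bonds along the chain from a sulfonamide nitrogen. Compound 4 is expected to show a step of a number 0.13 log units higher from compound 3 to compound 4 (within the scatter) in this assay, beside the earlier one, because the measured pair of compound 1 and compound 2 gave a number 0.06 log units lower from compound 1 to compound 2 (within the scatter). For compound 4 the estimate in this assay is -0.9, with a range from -1.4 to -0.4.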

Compound 4, distribution coefficient: -0.69
Compound 4: the middle estimate sits 0.21 log units below what was measured; low and high end bracket the measured number.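

In this assay the added methyl reads a number 0.34 log units higher from compound 3 to compound 4 (beyond the scatter) and is thus a modest step, whereas the same kind of change on the other core read a number 0.06 log units lower from compound 1 to compound 2 (within the scatter) and so did not register as a step at all. This shows that the change did not give the same reading on both cores, but it does not show that the core is what sets the outcome: the two pairs also differ in place, the methyl standing on a saturated chain carbon bound to a sulfonamide nitrogen in one and two bonds along the chain from a sulfonamide nitrogen in the other, and each case rests on a single pair. Nothing available bears on why the two steps read as they do.

The compounds shown leave open how a longer chain such as butyl, or an amine or a carboxylic acid at this place, would read in this assay on either core. They also leave open whether a methyl at the place it occupies in compound 4 would give a like step on the core of compound 1.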